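The source may report more compounds than this note shows. Statements on the series, on what has been measured and on what is new or still open speak of the compounds shown alone.

The compounds share one core, and compound 1 (`CC(C)[C@@H]1CC[C@@H](C)C[C@@]12N(C)C(=O)[C@@H]1[C@H]3C(=O)NC(=O)[C@H]3ON12`) carries the amide hydrogen on its ring nitrogen. In a functional assay, read by spectrophotometry, with a stated time of 2 h (a higher number here means a weaker inhibitor, a lower number a stronger inhibitor), compound 1 stands at "not determined" (no result reported), so it offers no number to start from. The change to compound 4 (`COc1ccc(N2C(=O)[C@H]3[C@H](ON4[C@@H]3C(=O)N(C)[C@@]43C[C@H](C)CC[C@H]3C(C)C)C2=O)cc1`) is 4-methoxyphenyl in place of hydrogen on an amide-type nitrogen in a ring.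

With no value for compound 1, no size or direction can be expected for this step itself, and the guidance has to come from the two measured compounds with an aromatic ring on that same nitrogen. Compound 2 (`CC(C)[C@@H]1CC[C@@H](C)C[C@@]12N(C)C(=O)[C@@H]1[C@H]3C(=O)N(c4ccccc4)C(=O)[C@H]3ON12`) gives 2310 ug/mL. Compound 3 (`CC(C)[C@@H]1CC[C@@H](C)C[C@@]12N(C)C(=O)[C@@H]1[C@H]3C(=O)N(c4ccc(Cl)cc4)C(=O)[C@H]3ON12`), with chloro in place of hydrogen on an aromatic carbon, gives 710 ug/mL. Going by the values given here, the one measured step, a 3.3-fold lower number from compound 2 to compound 3 (0.51 log units; beyond the scatter), is modest but beyond the scatter, and it is the only sign that a group on that aromatic ring can move the number in this assay. Among the compounds with values here, no measured compound carries the methoxy group, so the value is expected to lie around the span of these two numbers, without a firm direction. For compound 4 the estimated value is 1500 ug/mL, with an expected range of 550 ug/mL to 4000 ug/mL.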

Compound 4, half-maximal inhibitory concentration: 990 ug/mL
Beside the measured number, compound 4's estimate is 1.5-fold (0.18 log units) above it; measured number inside the range.
By their numbers in this assay, from the lowest: compounds 3 and 4 (each within the scatter of the next); then compound 2.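

In this assay the result gives a second substituent on the aromatic ring a reading, with a 2.3-fold lower number from compound 2 to compound 4 (0.37 log units; beyond the scatter) pointing the same way as a 3.3-fold lower number from compound 2 to compound 3 (0.51 log units; beyond the scatter), so the lower number no longer rests on chloro alone. Methoxy in place of chloro gives a 1.4-fold higher number from compound 3 to compound 4 (0.14 log units; within the scatter) and so does not separate the two groups in this assay, although they are different substituents. The change from the amide hydrogen to 4-methoxyphenyl on the ring nitrogen still cannot be read as a step, as compound 1 has no number to compare with compound 4.

The compounds shown leave open whether an amine, a carboxylic acid or a longer chain on the aromatic ring would follow compounds 3 and 4 or move the number further. They also leave open whether a simple alkyl chain on the ring nitrogen, in place of the aromatic ring, would give a number near those of the aryl compounds.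

Nothing among the data given here bears on what lies behind these numbers.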